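This account rests on a few compounds, and the source may have more. Where it says the series, first, only, none or still open, it means among the compounds named here.

Measured in an ADME assay on the whole organism for pharmacokinetics, with Rattus norvegicus as the target, at a dose of 2 mg/kg by the intravenous route; a lower number here means less compound in the circulation, a higher number more compound in the circulation at the dose given:
Compound 1 `COc1cc(C(=O)O)ccc1OCCCCOc1ccc(C(=O)CC(C)C)c(O)c1C`: 6430 nM
Compound 2 `Cc1c(OCCCCOc2ccc(C(=O)O)cc2)ccc(C(=O)CC(C)C)c1O`: 5000 nM

Among the measured compounds shown here, compound 2, at 5000 nM, lies within the scatter of compound 1, the only other measured compound. Compound 3 `Cc1c(OCCCCOc2ccc(F)c(C(=O)O)c2)ccc(C(=O)CC(C)C)c1O` carries 3-carboxy-4-fluorophenyl in place of 4-carboxyphenyl on an oxygen on a saturated carbon. For the measured compounds named here, the one measured step, a 1.3-fold lower number from compound 1 to compound 2 (0.11 log units; within the scatter), replaced methoxy with hydrogen on an aromatic carbon and stayed small. Going by the values given here, no measured step shows what fluorine or a relocated carboxy group does, so the range stays wide. In this assay the expected change is a 1.1-fold lower number from compound 2 to compound 3 (0.05 log units; within the scatter), with nothing expected beyond the scatter. The estimate for compound 3 is 4500 nM (range 1800 nM to 11000 nM).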

Compound 3, maximal plasma concentration: 3520 nM
Estimate against measurement, compound 3: 1.3-fold (0.11 log units) above; measured number inside the range.
By their numbers in this assay, from the lowest: compounds 3, 2 and 1 (each within the scatter of the next).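

In this assay, the change on an oxygen on a saturated carbon gives a 1.4-fold lower number from compound 2 to compound 3 (0.15 log units; within the scatter), so this step, like the earlier swap of methoxy for hydrogen, stays within the scatter. At this position, 3-carboxy-4-fluorophenyl can thus stand in for 4-carboxyphenyl with no clear shift in this read-out. Nothing measured here bears on what lies behind this result.

From the compounds shown here alone, the fluorine and the new carboxy placement arrive in one step, so their separate contributions stay open. Going by these compounds, whether a tetrazole or an amide in place of the carboxy group would behave alike also stays open.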